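Swapping One Side Group for Carbamoyl on Compound 2

The compounds below may be only part of what the source reports. "The series", "measured", "known", "first", "only" and "open" are said of these compounds alone.

Only limits are known so far in an ADME assay on cells (Erythrocyte, Homo sapiens), read by spectrophotometry and hemolysis, with a stated time of 24 h; a higher number here means a weaker inhibitor, a lower number a stronger inhibitor. Compound 1 `O=Cc1ccc(OCc2ccc3no[n+]([O-])c3c2)cc1` gives < 50 uM, which is a limit and not a number. Compound 2 `C=CCNC(=S)N/N=C/c1ccc(OCc2ccc3c(c2)=[N+]([O-])C(C)(C)[N+]=3[O-])cc1` gives > 100 uM, which is also a limit and not a number.

Compound 3 `CC1(C)[N+]([O-])=c2ccc(COc3ccc(/C=N/NC(N)=O)cc3)cc2=[N+]1[O-]` differs from compound 2 in one place: a group of 3 heavy atoms (1 carbon, 1 nitrogen, 1 oxygen; no ring) in place of a group of 6 heavy atoms (4 carbon, 1 nitrogen, 1 sulfur; no ring), on an amine nitrogen. The carbamoyl group enters on an amine nitrogen, where compound 2 carries a group with sulfur. Among the compounds with values here, no measured pair of compounds shows what such a swap does in this assay. Within the data shown here, the only guide is therefore the limit for compound 2 at > 100 uM. The estimated step that the limit leaves unreadable from compound 2 to compound 3 is expected to stay within the usual scatter, with no clear direction. The new measurement may well arrive as a limit again. The expected value for compound 3 is 130 uM, with an estimated range of 50 uM to 300 uM.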

Compound 3, concentration for 50% inhibition: > 200 uM
Compound 3: a limit, no number (the forecaster's own chance of this, stated with the estimate: 65%); middle value at least 1.5-fold (0.18 log units) away from the limit.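

Within the data shown here, compound 2 and compound 3 both give limits rather than numbers in this assay, so no step between them can be read. As far as these compounds go, whether putting carbamoyl in place of the sulfur-bearing group on the amine nitrogen changes the value at all, and in which direction, remains open.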